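Urea series: methoxy for trifluoromethyl on the terminal ring

A few compounds are considered here, and "the series" means these few. Any claim that something is new, unique, unknown or untested is made for them only; others in the source may bear on it.

Measured so far:
compound 1 `O=C(Nc1ccc(Cl)cc1)Nc1ccc(Nc2ncnc3c2OCCN3)cc1` gives 3070 nM in an assay on isolated protein for inhibition of proto-oncogene tyrosine-protein kinase receptor Ret (Homo sapiens), read by 33P incorporation, with stated times of 15 min and 40 min; on this read-out higher numbers stand for weaker inhibition and lower numbers for stronger inhibition
compound 2 `O=C(Nc1ccc(Nc2ncnc3c2OCCN3)cc1)Nc1ccc(C(F)(F)F)cc1` gives 306 nM in this assay

For the measured compounds named here, compound 2 stands lowest of the two numbers in this assay; the only other compound is compound 1, and the step of a 10-fold lower number from compound 1 to compound 2 (1.00 log units; beyond the scatter) is beyond the scatter. Compound 3 `COc1ccc(NC(=O)Nc2ccc(Nc3ncnc4c3OCCN4)cc2)cc1` is not yet measured. It differs from compound 2 by methoxy in place of trifluoromethyl on an aromatic carbon. Going by the values given here, the one step that bears on this position, a 10-fold lower number from compound 1 to compound 2 (1.00 log units; beyond the scatter), shows the number depending strongly on the group para to the large urea substituent. Among the compounds with values here, no step with methoxy exists, so the direction is uncertain; a higher number is expected, with a 4.9-fold higher number from compound 2 to compound 3 (0.69 log units; beyond the scatter). Compound 3 is estimated at 1500 nM, range 400 nM to 6000 nM.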

Compound 3, half-maximal inhibitory concentration: 227 nM
For compound 3 the middle estimate is 6.6-fold (0.82 log units) above the measured one; the whole stated range lies above it.
By their numbers in this assay, from the lowest: compounds 3 and 2 (each within the scatter of the next); then compound 1.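

In this assay, methoxy and trifluoromethyl at this position give numbers that cannot be told apart, with a 1.3-fold lower number from compound 2 to compound 3 (0.13 log units; within the scatter), even though the two groups differ in heavy atoms and hydrogen-bond acceptors. Against chloro the picture is different, with a 14-fold lower number from compound 1 to compound 3 (1.13 log units; beyond the scatter), so among these three groups chloro alone stands apart. No measurement at hand accounts for this split.

Open, as far as these compounds go, is whether an amine or a carboxylic acid here would match methoxy and trifluoromethyl or chloro. Also open, from the compounds shown here alone, is whether a longer alkoxy chain would keep the number of methoxy.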